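Swapping a Methoxyphenyl for a Naphthyl on the Urea

The source may hold more compounds than are shown below. What is called first, only, known or untested is meant among the compounds shown, and "the series" means these compounds.

Two ureas that share one core have been tested in an assay on isolated protein for inhibition of proto-oncogene tyrosine-protein kinase receptor Ret (Homo sapiens), read by 33P incorporation, with stated times of 15 min and 40 min; on this read-out lower numbers stand for stronger inhibition and higher numbers for weaker inhibition. Compound 1 `COc1ccc(NC(=O)Nc2ccc(Nc3ncnc4c3OCCN4)cc2)cc1` gives 227 nM. Within the data shown here, compound 2 `COc1cccc(NC(=O)Nc2ccc(Nc3ncnc4c3OCCN4)cc2)c1` gives 6810 nM, the higher of the two numbers, and the single measured step, a 30-fold higher number from compound 1 to compound 2 (1.48 log units; beyond the scatter), is large. Compound 3 `O=C(Nc1ccc(Nc2ncnc3c2OCCN3)cc1)Nc1cccc2ccccc12` differs from compound 2 in one place: naphthalen-1-yl in place of 3-methoxyphenyl on an amide-type nitrogen. Among the measured compounds shown here, no measured pair shows a naphthalen-1-yl group entering, so the only step that bears on the change is the one already seen, which shows that this part of the molecule can move the number a great deal. The direction for compound 3 is therefore uncertain, and a wide range is needed. Compound 3 is expected to give about 1500 nM, with a range from 150 nM to 15000 nM. This estimate means an expected 4.5-fold lower number from compound 2 to compound 3 (0.66 log units; beyond the scatter).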

Compound 3, half-maximal inhibitory concentration: > 10000 nM
Compound 3: no number, only a limit (the forecaster's own chance of this, stated with the estimate: 10%); middle value at least 6.6-fold (0.82 log units) away from the limit.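

In this assay compound 3 gives > 10000 nM, which is a limit of the assay and not a number: the limit of > 10000 nM in this assay, at which 1 of the 3 values shown sits.

Replacing 4-methoxyphenyl with naphthalen-1-yl on this nitrogen gives an at least 44-fold higher number from compound 1 to compound 3 (1.64 log units; beyond the scatter), so this position can also lose strength through a change of the whole aryl group, not only through moving a methoxy group around the ring. Replacing 3-methoxyphenyl with naphthalen-1-yl gives an at least 1.4-fold higher number from compound 2 to compound 3 (0.16 log units; that floor lies within the scatter), and since that floor lies within the scatter, no order can be claimed between these two groups, while 4-methoxyphenyl still holds the lowest number of the three.

The actual value for the naphthalen-1-yl compound remains unknown, and so does the cause of these losses. From the compounds shown here alone, it also remains open how a phenyl ring carrying an amine or a carboxylic acid in place of the methoxy group would read here.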